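A few compounds are considered here, and "the series" means these few. Any claim that something is new, unique, unknown or untested is made for them only; others in the source may bear on it.

Values in a functional assay on L02 cells (Homo sapiens) for cytotoxicity, read by MTT assay, with stated times of 48 h and 4 h; a lower number here means a stronger inhibitor, a higher number a weaker inhibitor:
- Compound 1 `O=[N+]([O-])c1ccc(/C=C/c2nc(NCCN3CCCCC3)c3ccccc3n2)cc1`: > 100000 nM (a limit of the assay, not a number)
- Compound 2 `CCN(CC)CCCNc1nc(/C=C/c2ccc([N+](=O)[O-])cc2)nc2ccccc12`: 5300 nM
- Compound 3 `NCCCCNc1nc(/C=C/c2ccc([N+](=O)[O-])cc2)nc2ccccc12`: 7460 nM

Compound 3 sits close to compound 2, with a 1.4-fold higher number from compound 2 to compound 3 (0.15 log units; within the scatter). Going by these compounds, only a limit is known for compound 1, so the comparison with it is open-ended.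

Compound 4 `NCCCCNc1nc(/C=C/c2ccc([N+](=O)[O-])cc2)nc2ccc(Cl)cc12` keeps the chain of compound 3 and carries chloro in place of hydrogen on an aromatic carbon of the shared core: chloro in place of hydrogen on an aromatic carbon.

The measured steps all change the amine chain. Two are large, an at least 18-fold lower number from compound 1 to compound 2 (1.27 log units; beyond the scatter) and an at least 13-fold lower number from compound 1 to compound 3 (1.12 log units; beyond the scatter), while the third is the small one given above. None of them touches the core, so they offer only indirect guidance, and the chain of compound 3 stays the same here. In this assay no shift beyond the scatter is therefore expected, with at most a slight move towards a lower number. The expected step is a 1.2-fold lower number from compound 3 to compound 4 (0.09 log units; within the scatter). For compound 4 the estimated value is 6000 nM, with an expected range from 2000 nM to 20000 nM.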

Compound 4, half-maximal inhibitory concentration: > 100000 nM
Compound 4 gave a limit, no number; the forecaster's own chance of this, stated with the estimate: 5%; middle value at least 16-fold (1.22 log units) away from the limit.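

In this assay, chloro in place of hydrogen on an aromatic carbon of the shared core, with the chain left unchanged, gives an at least 13-fold higher number from compound 3 to compound 4 (1.12 log units; beyond the scatter), so compound 4 is the weaker inhibitor. The earlier steps shown here all changed the amine chain, whereas this one shows that a change on the core alone can also move the number beyond the scatter, and the entering group is only 1 heavy atom, with no ring and no net charge. Going by these compounds, the true size of the step stays unknown, since the reading for compound 4 is a limit and not a number: the limit of > 100000 nM in this assay, at which 2 of the 4 values shown sit.

On these data alone, whether fluoro, methyl or methoxy on this same carbon would shift the number as far remains open. So does whether chloro would act in the same way alongside the diethylamino chain of compound 2.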